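Cyclopropyl Gives Way to Pyrazolyl on the Benzoyl Group

The compounds below may be only part of what the source reports. "The series", "measured", "known", "first", "only" and "open" are said of these compounds alone.

The three measured compounds and their values:

Compound 1 `CN1CCN(CCCS(=O)(=O)c2ccc3nc(NC(=O)NC(=O)c4cc(C5CC5)ccc4Cl)sc3c2)CC1`: in a physicochemical assay for lipophilicity (on this read-out lower numbers stand for lower lipophilicity and higher numbers for higher lipophilicity), compound 1 gives 2.9.
Compound 2 `CC(C)NCCS(=O)(=O)c1ccc2nc(NC(=O)NC(=O)c3ccccc3Cl)sc2c1`: in this assay compound 2 gives 2.3.
Compound 3 `CN1CCC(S(=O)(=O)c2ccc3nc(NC(=O)NC(=O)c4cc(N5CCCC5)c(C#N)cc4Cl)sc3c2)CC1`: in this assay compound 3 gives 3.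

Among these three numbers, compound 1 holds the second highest. Its nearest neighbour is compound 3, whose value lies higher by an amount within the usual scatter, so the two cannot be told apart on this read-out. Compound 2 stands furthest away, with a number lower than that of compound 1 by a gap that lies beyond the scatter.

Compound 4 `CN1CCN(CCCS(=O)(=O)c2ccc3nc(NC(=O)NC(=O)c4cccc(-n5cccn5)c4Cl)sc3c2)CC1` has not yet been measured in this assay. It differs from compound 1 in one place: 2-chloro-3-(1H-pyrazol-1-yl)phenyl in place of 2-chloro-5-cyclopropylphenyl on a carbonyl carbon. No pair of measured compounds that differ in a single place is available, so the size of this step has no direct precedent among the numbers shown. The account nevertheless expects the step from compound 1 to compound 4 to be a decrease that goes beyond the scatter, a number 0.90 log units lower from compound 1 to compound 4 (beyond the scatter). Compound 4 is therefore estimated at 2, with a range from 1.4 to 2.6.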

Compound 4, distribution coefficient: 1.6
The estimate for compound 4 lay 0.40 log units above the measured number; the range from low to high includes it.
By their numbers in this assay, from the lowest: compound 4; then compound 2; then compounds 1 and 3 (each within the scatter of the next).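

For the compounds shown here, with the rest of compound 1 held constant, this single exchange on a carbonyl carbon gives the first directly readable step in this assay: a number 1.30 log units lower from compound 1 to compound 4 (beyond the scatter). The earlier compounds shown here differ in more than one place and could not show that this part of the structure alone can move the read-out by so much, here with 2-chloro-3-(1H-pyrazol-1-yl)phenyl, which counts 2 hydrogen-bond acceptors, taking the place of 2-chloro-5-cyclopropylphenyl, which counts none. Nothing measured here bears on why the number moves so far.

The step changes both the ring carried by the 2-chlorophenyl group and the place of that ring, so the compounds shown leave open how much of it belongs to each; a 2-chloro-5-(1H-pyrazol-1-yl)phenyl or a 2-chloro-3-cyclopropylphenyl group on the same carbonyl carbon would separate the two. Also open, going by these compounds, is how either group compares with a plain 2-chlorophenyl group on the side chain of compound 1, and whether the step keeps its size on other side chains.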